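The source may hold more compounds than are shown below. What is called first, only, known or untested is meant among the compounds shown, and "the series" means these compounds.

Compound 1 `Oc1ccc2ccccc2c1/C=N/NC(=S)Nc1ccccc1`: 600 nM
Compound 2 `NC(=S)N/N=C/c1ccccc1O`: > 5000 nM, a limit
Compound 3 `CCN(CC)c1ccc(/C=N/NC(N)=S)c(O)c1`: > 5000 nM, a limit

All three were tested in a functional assay on MIA PaCa-2 cells (Homo sapiens) for antiproliferative activity, read by MTT assay, with a stated time of 72 h; on this read-out lower numbers stand for stronger inhibition and higher numbers for weaker inhibition. Compound 3 has no number on this read-out, only the limit > 5000 nM. Compound 2 is also held at a limit, > 5000 nM. Together they make up (the limit of > 5000 nM in this assay, at which 2 of the 3 values shown sit).

Compound 4 `CCN(CC)c1ccc(/C=N/NC(=S)Nc2ccccc2)c(O)c1` has not yet been measured. It differs from compound 3 in one place, with phenyl in place of hydrogen on an amide-type nitrogen. The same difference, cut one bond further out, reads amino to anilino.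

Going by the values given here, the only measured step between close neighbours is a step that the two limits leave unreadable from compound 2 to compound 3, which is diethylamino in place of hydrogen on an aromatic carbon. It offers no size to carry forward. Among the compounds with values here, the nearest guide is compound 1, the only measured compound with the anilino end, which gives a true number of 600 nM. Its core differs from that of compound 3, however, so it is a hint and not a step.

In this assay, a change toward stronger inhibition is therefore expected, of uncertain size, and compound 4 may still stop at the limit. The expected change is an at least 3.3-fold lower number from compound 3 to compound 4 (0.52 log units; beyond the scatter). For compound 4 the estimated value is 1500 nM, with an expected range of 300 nM to 5000 nM.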

Compound 4, half-maximal inhibitory concentration: 200 nM
Compound 4: the middle estimate sits 7.5-fold (0.88 log units) above what was measured; measured number below the stated range.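

Phenyl in place of hydrogen on the amide-type nitrogen gives an at least 25-fold lower number from compound 3 to compound 4 (1.39 log units; beyond the scatter) in this assay, and this is the first step between close neighbours here with a size that can be read, as the earlier step cannot be read. It shows that this nitrogen is a position where one change can carry a compound from a limit to a true number. Compound 4 gives 200 nM in this assay, while the amino end of compound 3 gave no number at all. The figure for the step is a floor and not a full size, and the real gap may be wider, as compound 3 holds only a limit: the limit of > 5000 nM in this assay, at which 2 of the 4 values shown sit.

The compounds shown leave open whether the same phenyl would give a step of like size without the diethylamino group, on the plain core of compound 2. They also leave open whether the aromatic ring itself matters on this nitrogen, or whether a methyl, a cyclohexyl or a benzyl group in its place would do the same.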